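The source may hold more compounds than are shown below. What is called first, only, known or untested is meant among the compounds shown, and "the series" means these compounds.

Measured so far in a functional assay on NCI-H460 cells (Homo sapiens) for antiproliferative activity, read by CCK-8 assay, with a stated time of 72 h, tested at 8 uM; on this read-out lower numbers stand for a weaker effect and higher numbers for a stronger effect at the one concentration tested:
compound 1 `CC1CCN(c2nc(Cl)nc3c2ncn3Cc2ccc(/C=C/C(=O)Nc3ccccc3N)cc2)CC1` gives 10.8%
compound 2 `Nc1ccccc1NC(=O)/C=C/c1ccc(Cn2cnc3c(Nc4cccc(Cl)c4)nc(Cl)nc32)cc1` gives 29.4%
compound 3 `CC1CCN(c2nc(Cl)nc3c2ncn3Cc2ccc(C(=O)Nc3ccccc3N)cc2)CC1` gives 40.9%

Compound 3 is the highest of the three, with both steps to it beyond the scatter. Within the core of compound 1, the change (3-chlorophenyl)amino in place of 4-methylpiperidin-1-yl on an aromatic carbon gave a number 18.6 percentage points higher from compound 1 to compound 2 (beyond the scatter). Changing the core itself, ((2-aminophenyl)carbamoyl in place of 2-((2-aminophenyl)carbamoyl)ethenyl on an aromatic carbon), gave a number 30.1 percentage points higher from compound 1 to compound 3 (beyond the scatter).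

Compound 4 `Nc1ccccc1NC(=O)c1ccc(Cn2cnc3c(Nc4cccc(Cl)c4)nc(Cl)nc32)cc1` is not yet measured. It repeats the change of compound 1 to compound 2 on the core of compound 3: (3-chlorophenyl)amino in place of 4-methylpiperidin-1-yl on an aromatic carbon. Both occurrences of this change sit at a place described in the same words, so it is the same change, made twice in all. On the expectation that the step seen as a number 18.6 percentage points higher from compound 1 to compound 2 (beyond the scatter) carries over to the other core, compound 4 is expected to show a number 16.1 percentage points higher from compound 3 to compound 4 (beyond the scatter) in this assay. Compound 4 is estimated at 57%, between 40% and 75%.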

Compound 4, a percentage reported as inhibition, at one concentration (the size of the read-out at that concentration, not a potency): 67%
For compound 4 the middle estimate is 10 percentage points below the measured one; the range from low to high includes it.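

In this assay, (3-chlorophenyl)amino in place of 4-methylpiperidin-1-yl carried over to the second core, giving a number 26.1 percentage points higher from compound 3 to compound 4 (beyond the scatter), in line with the earlier step: the same change on two cores in this assay, a number 18.6 percentage points higher (beyond the scatter) from compound 1 to compound 2 and a number 26.1 percentage points higher (beyond the scatter) from compound 3 to compound 4, 7.5 percentage points apart, within the scatter of two such steps. The change from 2-((2-aminophenyl)carbamoyl)ethenyl to (2-aminophenyl)carbamoyl also repeated, giving a number 37.6 percentage points higher from compound 2 to compound 4 (beyond the scatter): the same change on two cores in this assay, a number 30.1 percentage points higher (beyond the scatter) from compound 1 to compound 3 and a number 37.6 percentage points higher (beyond the scatter) from compound 2 to compound 4, 7.5 percentage points apart, within the scatter of two such steps. These four compounds show the two changes holding on each other's background at one concentration, but they give no potency and do not show that either change transfers to any core beyond those shown.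

Open, going by these compounds, is whether another amine at this place, such as morpholine or unsubstituted aniline, gives a similar step. Also open, on these data alone, is whether a methoxy group in place of the chloro group on the shared core alters it.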